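The source may hold more compounds than are shown below. What is called first, only, known or untested is meant among the compounds shown, and "the series" means these compounds.

Compound 3 `CCCCNCc1ccc(Cl)c(-c2ccccc2OC)c1` was tested in a functional assay on HEK293 cells for agonist activity at 5-hydroxytryptamine receptor 7 (Homo sapiens), read by cAMP accumulation, with a stated time of 30 min (a lower number here means a smaller maximal response, a higher number a larger maximal response), and returned no single number; the assay recorded it as "not active" (no number reported). It does not stand alone in this: compound 1 `CCCN(CCC)Cc1ccc(Cl)c(-c2ccccc2OC)c1` also gave "not active" (no number reported) in this assay, so two of the three measured compounds carry no number at all. Only compound 2 `CNCc1ccc(Cl)c(-c2ccccc2OC)c1` produced a value, reaching 72% in this assay.

Compound 4 `CCN(CC)Cc1ccc(Cl)c(-c2ccccc2OC)c1` has not yet been measured. It has the same atoms as compound 3, joined differently: diethylamino in place of butylamino on a saturated chain carbon bound to an aromatic carbon. Within the data shown here, no measured pair shows exactly this change, so the size of the step it brings in this assay cannot be read from the data. With compound 3 recorded as "not active" (no number reported) and compound 1 recorded as "not active" (no number reported), while only compound 2, at 72%, gives a number, the expectation for compound 4 is a small maximal response in this assay, with a real chance that the assay again reports no number rather than a value, and no reason to expect any rise beyond the usual scatter. Compound 4 is therefore estimated at 20%, within a range from 0% to 55%.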

Compound 4, largest response reached (Emax), in percent of the reference or control that the assay uses: "not active" (no number reported)
No number was reported for compound 4; there is nothing to compare the estimate with.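

In this assay, among these compounds, compound 3 and compound 4 both carry no number, so the change from butylamino to diethylamino gives no step that can be read. Still open, from the compounds shown here alone, is how the maximal response varies with the amine group, with only compound 2 at 72% giving a number. No measurement shown offers an explanation for these results.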